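This account rests on a few compounds, and the source may have more. Where it says the series, first, only, none or still open, it means among the compounds named here.

Two close analogues have been measured in an ADME assay on a cell-free system (plasma, Mus musculus) for protein binding; a higher number here means a larger unbound share of the compound, a lower number a smaller unbound share. Compound 1 `Cc1cc(C)c(-c2ncc[nH]2)cc1NC(=O)c1ccc(OCc2ccccn2)cc1` gives 0.033, while compound 2 `Cc1cc(C)c(-c2cn(C)cn2)cc1NC(=O)c1ccc(OCc2ccccn2)cc1` gives 0.012, the lower of the two numbers. Among the measured compounds shown here, the only measured step, a 2.8-fold lower number from compound 1 to compound 2 (0.44 log units; beyond the scatter), comes from exchanging 1H-imidazol-2-yl for 1-methyl-1H-imidazol-4-yl on an aromatic carbon. For the measured compounds named here, it is therefore the one piece of evidence about this place on the shared core.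

Compound 3 `Cc1cc(C)c(-c2ccc(N)nn2)cc1NC(=O)c1ccc(OCc2ccccn2)cc1` changes the same place, with 6-aminopyridazin-3-yl in place of 1-methyl-1H-imidazol-4-yl on an aromatic carbon. The group stands on an aromatic carbon of a six-membered aromatic ring of carbon only, ortho to a methyl group and para to a methyl group. Going by the values given here, no measured compound carries 6-aminopyridazin-3-yl, so one step is thin support. Still, compound 1 at 0.033 shows that a different group here can give a higher number than compound 2 does, and a modest rise in this assay is expected. The expected step is a 2.1-fold higher number from compound 2 to compound 3 (0.32 log units; beyond the scatter). For compound 3 the estimated unbound fraction is 0.025, with an expected range from 0.01 to 0.06.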

Compound 3, unbound fraction in the Mus musculus assay: 0.029
Compound 3: the middle estimate sits 1.2-fold (0.06 log units) below what was measured, and the stated range covers the measured number.
By their numbers in the Mus musculus assay, from the lowest: compound 2; then compounds 3 and 1 (each within the scatter of the next).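

In the Mus musculus assay, this place on the shared core now gives a 2.4-fold higher number from compound 2 to compound 3 (0.38 log units; beyond the scatter), so a second group, with a six-membered rather than a five-membered aromatic ring, also stands clear of 1-methyl-1H-imidazol-4-yl. In the Mus musculus assay, 6-aminopyridazin-3-yl and 1H-imidazol-2-yl cannot be told apart, with a 1.1-fold lower number from compound 1 to compound 3 (0.06 log units; within the scatter), so compound 2 is the only one of the three that stands apart from the others. In a physicochemical assay for lipophilicity (a higher number here means a more lipophilic compound, a lower number a more polar compound), compound 2 gives 3 and compound 3 gives 2.6. The larger unbound share of compound 3 compared with compound 2 may reflect its lower lipophilicity, as measured in the physicochemical assay: the measured distribution coefficient of compound 2, 3, and of compound 3, 2.6, a number 0.40 log units lower (beyond the scatter)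

This single pair cannot show whether the unbound share follows lipophilicity across other groups at this place, and compound 1 offers no test of it here. Going by these compounds, it also remains open what the amine of 6-aminopyridazin-3-yl contributes, and how the unbound share would respond to a methoxy group in its place or to a carboxylic acid on the ring.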